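Aminopyrimidine series: swapping the benzylamine for an anilide

This account rests on a few compounds, and the source may have more. Where it says the series, first, only, none or still open, it means among the compounds named here.

For the measured compounds named here, compound 2 `COc1cccc(CNc2nc(Nc3ccc(N4CCN(C)CC4)cn3)ncc2Cl)c1` in a functional assay on MCF7 cells (Homo sapiens) for inhibition, read by CCK-8 assay, with a stated time of 48 h (a higher number here means a weaker inhibitor of growth, a lower number a stronger inhibitor of growth), gives 19500 nM, the only numerical reading so far. Compound 1 `Cc1ccccc1Nc1nc(NCc2ccccc2)ncc1Cl` sits at a limit of this assay, > 100000 nM, not a number (the limit of > 100000 nM in this assay, at which 1 of the 2 values shown sits). The change to compound 3 `CN1CCN(c2ccc(Nc3ncc(Cl)c(Nc4ccc(C(C)(C)C)cc4)n3)nc2)CC1` is 4-(tert-butyl)phenyl in place of 3-methoxybenzyl on a nitrogen on an aromatic ring. Going by the values given here, no measured pair with a single change exists here, so the size of the step is uncertain; a shift of modest size in either direction, possibly none beyond the scatter, is expected, and the estimated step is a 1.3-fold lower number from compound 2 to compound 3 (0.11 log units; within the scatter). For compound 3 the expected result in this assay is 15000 nM, within the range 3000 nM to 80000 nM.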

Compound 3, concentration for 50% growth inhibition: 12600 nM
Beside the measured number, compound 3's estimate is 1.2-fold (0.08 log units) above it, and the stated range covers the measured number.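

In this assay the first pair differing in one place gives a step (a 1.5-fold lower number from compound 2 to compound 3 (0.19 log units; within the scatter)), so exchanging 3-methoxybenzyl for 4-(tert-butyl)phenyl on this nitrogen leaves the reading unchanged within the scatter. At this position, then, the loss of the methoxy oxygen and the change to the larger 4-(tert-butyl)phenyl group do not separate the two compounds in this assay. The data shown give no reason for this result. Still open, going by these compounds, is whether a basic amine or a carboxylic acid on this ring, or a longer chain on this nitrogen, would shift the reading beyond the scatter.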